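One Methyl Group, Two Places, One Cell Line

This account rests on a few compounds, and the source may have more. Where it says the series, first, only, none or still open, it means among the compounds named here.

Four related compounds are compared in a functional assay on DU-145 cells (Homo sapiens) for cytotoxicity, read by MTT assay, with a stated time of 48 h; a higher number here means a weaker inhibitor, a lower number a stronger inhibitor. Compound 1 `CCOC(=O)c1c(-c2c(Cl)c3ccccc3oc2=O)nn(-c2cccc(Cl)c2)c1C(=O)OCC` gives 24000 nM in this assay. Compound 2 `CCOC(=O)c1c(-c2c(Cl)c3cc(C)ccc3oc2=O)nn(-c2cccc(Cl)c2)c1C(=O)OCC` differs from it by methyl in place of hydrogen on an aromatic carbon and gives 156000 nM; the step of a 6.5-fold higher number from compound 1 to compound 2 (0.81 log units; beyond the scatter) shows that this single added carbon weakened the effect. Compound 3 `CCOC(=O)c1c(-c2cc3ccc(OC)cc3oc2=O)nn(-c2ccccc2)c1C(=O)OCC` has a different core, and how its core differs from that of compound 1 is not broken down here; in this assay compound 3 gives 33000 nM, which sits within the scatter of the number for compound 1.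

Compound 4 `CCOC(=O)c1c(-c2cc3ccc(OC)cc3oc2=O)nn(-c2cccc(C)c2)c1C(=O)OCC` is the unmeasured member of the set. It differs from compound 3 by methyl in place of hydrogen on an aromatic carbon. Going by the values given here, this is the same kind of change as the one from compound 1 to compound 2, but not the same: in compound 2 the methyl sits on an aromatic carbon of a ring that is part of a fused or bridged system of two rings, meta to a fused ring and para to a fused ring, whereas in compound 4 it sits on a six-membered aromatic ring of carbon only, meta to a large group. Among the compounds with values here, because the only measured example, a 6.5-fold higher number from compound 1 to compound 2 (0.81 log units; beyond the scatter), points toward a higher number, compound 4 is expected to move in the same direction, though the different place leaves the size uncertain, and the expected step is a 1.7-fold higher number from compound 3 to compound 4 (0.22 log units; within the scatter). The estimate for compound 4 in this assay is 55000 nM, expected to fall between 18000 nM and 180000 nM.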

Compound 4, half-maximal inhibitory concentration: 35000 nM
Beside the measured number, compound 4's estimate is 1.6-fold (0.20 log units) above it; the range from low to high includes it.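

On the core of compound 3, phenyl to 3-methylphenyl gives a 1.1-fold higher number from compound 3 to compound 4 (0.03 log units; within the scatter) in this assay, a step too small to read as a real difference. The same kind of change, methyl in place of hydrogen on an aromatic carbon, therefore does not carry a fixed size from one core to the other in this series, and the larger effect seen on the first core cannot simply be transferred to the second: the same change on two cores in this assay, a 6.5-fold higher number (0.81 log units; beyond the scatter) from compound 1 to compound 2 and a 1.1-fold higher number (0.03 log units; within the scatter) from compound 3 to compound 4, 6.1-fold (0.79 log units) apart, beyond the scatter of two such steps. What this does not show is the source of the gap, since the two methyl groups sit in different places and the two cores are not the same, and these two steps cannot separate one of those differences from the other.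

The compounds shown leave open whether a methyl group at the place it holds in compound 2, but on the core of compound 3, would give a step like the larger one or like the smaller one. They also leave open what a group other than methyl, such as an amine or a carboxylic acid, would do on the same carbon of the aromatic ring that carries the methyl in compound 4.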